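The compounds below may be only part of what the source reports. "The series", "measured", "known", "first", "only" and "open" are said of these compounds alone.

In a functional assay on SK-MEL-28 cells (Homo sapiens) for inhibition, read by sulforhodamine B assay, with a stated time of 48 h (on this read-out lower numbers stand for stronger inhibition of growth and higher numbers for weaker inhibition of growth), compound 1 `COc1cc(-c2nn(-c3cccc(NC(=O)c4cccc(C(F)(F)F)c4)c3)cc2-c2ccncc2)ccc1Cl` gives 2490 nM, compound 2 `COc1cc(-c2nn(-c3cccc(NC(=O)Nc4ccc(Cl)c(Cl)c4)c3)cc2-c2ccncc2)ccc1Cl` gives 1430 nM and compound 3 `COc1cc(-c2nn(-c3cccc(NC(=O)Nc4cccc(C(F)(F)F)c4)c3)cc2-c2ccncc2)ccc1Cl` gives 1120 nM. Compound 3 stands level with compound 2, since the data show a 1.3-fold lower number from compound 2 to compound 3 (0.11 log units; within the scatter), and clear of compound 1, with a 2.2-fold lower number from compound 1 to compound 3 (0.35 log units; beyond the scatter), a modest step. Compound 4 `COc1cc(-c2nn(-c3cccc(NC(=O)Nc4ccc(Cl)c(C(F)(F)F)c4)c3)cc2-c2ccncc2)ccc1Cl` differs from compound 3 by chloro in place of hydrogen on an aromatic carbon, which turns 3-(trifluoromethyl)phenyl into 4-chloro-3-(trifluoromethyl)phenyl.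

Going by the values given here, no measured step adds a chloro alone. The closest evidence is the exchange of 3,4-dichlorophenyl for 3-(trifluoromethyl)phenyl, a 1.3-fold lower number from compound 2 to compound 3 (0.11 log units; within the scatter). The other step between ureas and amide, a 1.7-fold lower number from compound 1 to compound 2 (0.24 log units; within the scatter), changes the carbonyl substituent and bears on this only loosely. On that basis no change beyond the scatter is expected in this assay, and the expected result is a 1.2-fold lower number from compound 3 to compound 4 (0.09 log units; within the scatter). For compound 4 the estimated value is 900 nM, with an expected range of 400 nM to 2000 nM.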

Compound 4, concentration for 50% growth inhibition: 1200 nM
Estimate against measurement, compound 4: 1.3-fold (0.12 log units) below; the measured number falls inside the stated range.
By their numbers in this assay, from the lowest: compounds 3, 4, 2 and 1 (each within the scatter of the next, the first and the last beyond it).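

In this assay, going by these compounds alone, a chloro placed ortho to a trifluoromethyl group and para to a large group, which turns 3-(trifluoromethyl)phenyl into 4-chloro-3-(trifluoromethyl)phenyl, gives the first direct reading at this position, and it stays within the scatter, with a 1.1-fold higher number from compound 3 to compound 4 (0.03 log units; within the scatter). Trifluoromethyl in place of chloro on an aromatic carbon also stays within the scatter, with a 1.2-fold lower number from compound 2 to compound 4 (0.08 log units; within the scatter), while the step from the amide to this urea lies beyond it, with a 2.1-fold lower number from compound 1 to compound 4 (0.32 log units; beyond the scatter), although compound 2 remains within the scatter of compound 1. Nothing available explains why the added chloro leaves the number in this range.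

As far as these compounds go, it remains open whether a fluoro, a methoxy or an amine at this same position would also stay within the scatter. From the compounds shown here alone, it is equally open whether a carboxylic acid or a longer chain there would shift the number.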